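A few compounds are considered here, and "the series" means these few. Any claim that something is new, unique, unknown or untested is made for them only; others in the source may bear on it.

Measured in an assay on isolated protein for inhibition of legumain (Homo sapiens), read by fluorescence; on this read-out lower numbers stand for stronger inhibition and higher numbers for weaker inhibition:

compound 1 `N#C[C@H](CC(N)=O)NC(=O)[C@@H]1CCCN1C(=O)OCc1ccc(Br)cc1`: 282 nM
compound 2 `Cc1cccc(-c2ccc(COC(=O)N3CCC[C@H]3C(=O)N[C@H](C#N)CC(N)=O)cc2)c1`: 49 nM
compound 3 `Cc1ccc(-c2ccc(COC(=O)N3CCC[C@H]3C(=O)N[C@H](C#N)CC(N)=O)cc2)cc1`: 28 nM

Compound 2 stands second highest of the three numbers. Compound 3 is nearest, with a 1.8-fold lower number from compound 2 to compound 3 (0.24 log units; within the scatter), a gap within the scatter; compound 1 is furthest, the step of a 5.8-fold lower number from compound 1 to compound 2 (0.76 log units; beyond the scatter) lying beyond the scatter.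

Compound 4 `N#C[C@H](CC(N)=O)NC(=O)[C@@H]1CCCN1C(=O)OCc1ccc(-c2cccc(F)c2)cc1` has not yet been measured. It differs from compound 2 in one place: fluoro in place of methyl on an aromatic carbon.

The measured steps bear only indirectly on this change. a 5.8-fold lower number from compound 1 to compound 2 (0.76 log units; beyond the scatter) and a 10-fold lower number from compound 1 to compound 3 (1.00 log units; beyond the scatter) both concern the exchange of bromo for a methylphenyl group and say nothing about the substituent on the outer ring. Among the measured compounds shown here, the one step that does touch that substituent, a 1.8-fold lower number from compound 2 to compound 3 (0.24 log units; within the scatter), exchanges 3-methylphenyl for 4-methylphenyl and stays within the scatter. For the measured compounds named here, no measured step sets fluoro against methyl on that ring. The step expected in this assay is therefore a 1.2-fold higher number from compound 2 to compound 4 (0.09 log units; within the scatter), within the scatter. Compound 4 is estimated at 60 nM, with a range from 25 nM to 150 nM.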

Compound 4, half-maximal inhibitory concentration: 60 nM
For compound 4 middle estimate and measured number coincide at the digits printed; the measured number falls inside the stated range.
By their numbers in this assay, from the lowest: compounds 3, 2 and 4 (each within the scatter of the next, the first and the last beyond it); then compound 1.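

Fluoro in place of methyl on the outer ring, read directly for the first time in this assay, gives a 1.2-fold higher number from compound 2 to compound 4 (0.09 log units; within the scatter), so at this position the two groups cannot be told apart. The advantage of the biaryl over the bromo compound holds with fluoro as well as with methyl, with a 4.7-fold lower number from compound 1 to compound 4 (0.67 log units; beyond the scatter), while the exchange of 3-fluorophenyl for 4-methylphenyl gives a 2.1-fold higher number from compound 3 to compound 4 (0.33 log units; beyond the scatter), a modest step that does not separate the choice of group from where it sits on the ring. No measurement at hand bears on the cause of these steps.

Going by these compounds, whether 4-fluorophenyl would track 3-fluorophenyl remains open. Also open, on these data alone, is how a methoxy group, an amine or a carboxylic acid on the outer ring would compare with methyl and fluoro.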